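Hydroxyl for Methyl on the Benzyl Arm of an Indole

The source may report more compounds than this note shows. Statements on the series, on what has been measured and on what is new or still open speak of the compounds shown alone.

Among the measured compounds shown here, compound 2 `Cc1ccc(Cn2cncc2-c2cc3cc(Br)ccc3[nH]2)cc1` gives 4290 nM in an assay on HEK293 cells for inhibition of Indoleamine 2,3-dioxygenase 1 (Homo sapiens), with a stated time of 30 min (on this read-out higher numbers stand for an effect only at larger amounts of compound and lower numbers for an effect already at smaller amounts), the lower of the two numbers measured so far. Compound 1 `c1ccc(Cn2cncc2-c2cc3ccccc3[nH]2)cc1` gives 10800 nM in this assay, a gap that lies beyond the usual scatter. These two compounds differ in more than one place, so no single step can be read from them. Compound 3 `Oc1ccccc1Cn1cncc1-c1cc2cc(Br)ccc2[nH]1` has not yet been measured; it differs from compound 2 in this way: 2-hydroxyphenyl in place of 4-methylphenyl on a saturated chain carbon bound to an aromatic nitrogen. For the measured compounds named here, nothing measured so far shows what such a change does on this core, since compound 1 and compound 2 differ elsewhere as well. The step is therefore expected to be small, in no firm direction, and within the scatter: a 1.1-fold lower number from compound 2 to compound 3 (0.03 log units; within the scatter). Compound 3 is estimated to give 4000 nM in this assay, with a range from 1400 nM to 12000 nM.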

Compound 3, half-maximal effective concentration: 5010 nM
Estimate against measurement, compound 3: 1.3-fold (0.10 log units) below; low and high end bracket the measured number.
By their numbers in this assay, from the lowest: compounds 2 and 3 (each within the scatter of the next); then compound 1.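

In this assay, among the compounds shown here, this is the first step on the shared core that can be read in one place: a 1.2-fold higher number from compound 2 to compound 3 (0.07 log units; within the scatter). On a saturated chain carbon bound to an aromatic nitrogen, 2-hydroxyphenyl can therefore take the place of 4-methylphenyl with the two numbers staying within the scatter of each other, although the entering group brings one hydrogen-bond donor and one hydrogen-bond acceptor and the leaving group has neither. No supporting data bear on why the numbers stay this close.

As far as these compounds go, it remains open whether the same holds for an amine, a carboxylic acid or a methoxy group on that phenyl ring, or for a longer chain to it. From the compounds shown here alone, the step between compound 1 and compound 2 cannot be read, so the separate contributions of the bromine and the methyl also remain open.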